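A few compounds are considered here, and "the series" means these few. Any claim that something is new, unique, unknown or untested is made for them only; others in the source may bear on it.

Compound 1 `O=C(CSc1nc(Nc2ccccc2)c2ccccc2n1)Nc1ccc(Cl)cc1Cl` and compound 2 `O=C(CSc1nc(Nc2ccccc2)c2ccccc2n1)Nc1ccc(F)c(Cl)c1` share one core and differ only at the amide. In a functional assay on PC-3 cells (Homo sapiens) for inhibition, read by MTT assay, with a stated time of 72 h (a lower number here means a stronger inhibitor, a higher number a weaker inhibitor), compound 2 gives 15500 nM, and compound 1 gives 9110 nM. The step of a 1.7-fold lower number from compound 2 to compound 1 (0.23 log units; within the scatter) belongs to the change (2,4-dichlorophenyl in place of 3-chloro-4-fluorophenyl on an amide-type nitrogen). Compound 3 `C=CC(=O)Nc1cccc(NC(=O)CSc2nc(Nc3ccc(F)c(Cl)c3)c3ccccc3n2)c1` has a different core; how it differs from compound 2 is not broken down here. In this assay compound 3 reaches only > 50000 nM, a limit of the assay rather than a number, matching (the limit of > 50000 nM in this assay, at which 1 of the 3 values shown sits). Compound 4 `C=CC(=O)Nc1cccc(NC(=O)CSc2nc(Nc3ccc(Cl)cc3Cl)c3ccccc3n2)c1` is not yet measured and differs from compound 3 by 2,4-dichlorophenyl in place of 3-chloro-4-fluorophenyl on a nitrogen on an aromatic ring. This is the same kind of change as that between compound 2 and compound 1, though there the group sat on an amide-type nitrogen whose other neighbour is a carbonyl carbon, while here it sits on a nitrogen on an aromatic ring whose other neighbour is aromatic carbon. Given a 1.7-fold lower number from compound 2 to compound 1 (0.23 log units; within the scatter), compound 4 is expected to stay near that limit, an expected step that the limit leaves unreadable from compound 3 to compound 4. Compound 4 is estimated at 60000 nM in this assay, between 25000 nM and 200000 nM.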

Compound 4, half-maximal inhibitory concentration: 25700 nM
For compound 4 the middle estimate is 2.3-fold (0.37 log units) above the measured one, within the range that was stated.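

In this assay the same change on the second core gives an at least 1.9-fold lower number from compound 3 to compound 4 (0.28 log units; that floor lies within the scatter). Compound 3 stands at a limit of the assay, not at a number, so this step is only a floor: the limit of > 50000 nM in this assay, at which 1 of the 4 values shown sits. The result therefore shows neither that the change carries the same size from one core to the other nor that it differs between them: the same change on two cores in this assay, a 1.7-fold lower number (0.23 log units; within the scatter) from compound 2 to compound 1 and an at least 1.9-fold lower number (0.28 log units; that floor lies within the scatter) from compound 3 to compound 4; the limit leaves it open whether they differ.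

The compounds shown leave open how the number in this assay would respond if an amine or a carboxylic acid replaced a halogen on either phenyl group. They also leave open whether a longer chain between the sulfur and the amide carbonyl would alter the step seen with this change.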